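Benzyl for cyclohexyl on the amide-type nitrogen

A few compounds are considered here, and "the series" means these few. Any claim that something is new, unique, unknown or untested is made for them only; others in the source may bear on it.

Among the compounds with values here, in a functional assay on MDA-MB-231 cells (Homo sapiens) for cytotoxicity, read by MTT assay, with a stated time of 48 h (a lower number here means a stronger inhibitor, a higher number a weaker inhibitor), the three measured members all return a limit rather than a number. Compound 1 `O=C(NCc1ccccc1)c1cc(Oc2cccc(NC(=S)Nc3ccc(Cl)cc3)c2)ccn1` gives > 100000 nM, which is a limit of the assay. Compound 2 `CNC(=O)c1cc(Oc2cccc(NC(=S)Nc3cccc(C(F)(F)F)c3)c2)ccn1` gives > 100000 nM, again a limit. Compound 3 `O=C(NC1CCCCC1)c1cc(Oc2cccc(NC(=S)Nc3cccc(C(F)(F)F)c3)c2)ccn1` gives > 100000 nM, also a limit. Compound 3 therefore stands at the limit that every value shown shares (the limit of > 100000 nM in this assay, at which 3 of the 3 values shown sit). Within the data shown here, the single one-site step among the measured compounds, a step that the two limits leave unreadable from compound 2 to compound 3, runs between two limits and its size cannot be read.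

Compound 4 `O=C(NCc1ccccc1)c1cc(Oc2cccc(NC(=S)Nc3cccc(C(F)(F)F)c3)c2)ccn1` differs from compound 3 by benzyl in place of cyclohexyl on an amide-type nitrogen. Among the measured compounds shown here, no measured step isolates this change; the nearest point of comparison is compound 1, which carries the same benzylcarbamoyl group with a different substituent elsewhere and also sits at the limit. For the measured compounds named here, with every value shown at the limit and the only measured step unreadable, no movement beyond the scatter can be read in either direction, and the expectation is that compound 4 also returns a limit. The step that the limit leaves unreadable from compound 3 to compound 4 is expected to be small. Compound 4 is estimated at 150000 nM, in the range 50000 nM to 500000 nM, and is most likely to be reported as a limit.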

Compound 4, half-maximal inhibitory concentration: 75000 nM
Beside the measured number, compound 4's estimate is 2.0-fold (0.30 log units) above it; the range from low to high includes it.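

In this assay compound 4 gives 75000 nM, the only number rather than a limit among the members shown. Compounds 1, 2 and 3 each remain at a limit: the limit of > 100000 nM in this assay, at which 3 of the 4 values shown sit. The readable steps are an at least 1.3-fold lower number from compound 3 to compound 4 (0.12 log units; that floor lies within the scatter), an at least 1.3-fold lower number from compound 1 to compound 4 (0.12 log units; that floor lies within the scatter) and an at least 1.3-fold lower number from compound 2 to compound 4 (0.12 log units; that floor lies within the scatter), so among these compounds a number appears only where benzyl on the amide-type nitrogen occurs together with 3-(trifluoromethyl)phenyl, although each floor lies within the scatter and the true size of these steps stays undefined.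

The remaining steps among the shown compounds cannot be read, so the effect of cyclohexyl in place of methyl on the amide-type nitrogen remains unknown. On these data alone, it also remains open whether a longer chain between the amide-type nitrogen and the phenyl ring, or a benzyl group carrying an amine or a carboxylic acid, would give a number clearly beyond the scatter from that of compound 4 in this assay.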